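This account rests on a few compounds, and the source may have more. Where it says the series, first, only, none or still open, it means among the compounds named here.

Measured so far in a functional assay on A549 cells (Homo sapiens) for antiproliferative activity, read by MTT assay, with a stated time of 72 h; a lower number here means a stronger inhibitor, a higher number a weaker inhibitor:
- Compound 1 `COc1cc2c(Nc3ccc(C#N)cc3)ncnc2cc1OCCCN1CCC(O)CC1`: 29900 nM
- Compound 2 `COc1cc2c(Nc3ccc(C#N)cc3)ncnc2cc1OCCCN1CCCCC1CCO`: > 100000 nM, a limit of the assay and not a number
- Compound 3 `COc1cc2c(Nc3ccc(C#N)cc3)ncnc2cc1OCCCN1CCN(C)CC1`: 48800 nM

Compound 3 lies within the scatter of compound 1, with a 1.6-fold higher number from compound 1 to compound 3 (0.21 log units; within the scatter). Against compound 2, the series shows an at least 2.0-fold lower number from compound 2 to compound 3 (0.31 log units; beyond the scatter).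

The next compound is compound 4 `COc1cc2c(Nc3cccc(C#N)c3)ncnc2cc1OCCCN1CCN(C)CC1`, which has 3-cyanophenyl in place of 4-cyanophenyl on a nitrogen on an aromatic ring.

All three measured steps exchange the group on the saturated chain carbon, and none touches the cyanophenyl group. They therefore bear on this change only indirectly. Going by the values given here, the one step from compound 1 that goes beyond the scatter is an at least 3.3-fold higher number from compound 1 to compound 2 (0.52 log units; beyond the scatter), and it ends at a limit. Among the compounds with values here, with no measured precedent for the change, no step beyond the scatter is expected in this assay, in either direction.

The expected result is a 1.1-fold lower number from compound 3 to compound 4 (0.04 log units; within the scatter). For compound 4 the estimated value is 45000 nM, with an expected range of 15000 nM to 100000 nM.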

Compound 4, half-maximal inhibitory concentration: 27700 nM
Compound 4: middle estimate off by 1.6-fold (0.21 log units), on the high side, within the range that was stated.
By their numbers in this assay, from the lowest: compounds 4, 1 and 3 (each within the scatter of the next). At a limit, above all of these: compound 2.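

In this assay, 3-cyanophenyl in place of 4-cyanophenyl on a nitrogen on an aromatic ring gives a 1.8-fold lower number from compound 3 to compound 4 (0.25 log units; within the scatter) and so does not separate the two groups. Going by these compounds alone, the earlier compounds all carry 4-cyanophenyl, which makes this step the only reading of the aryl group, and it holds only with 4-methylpiperazin-1-yl on the chain. No measured property shown here bears on this result.

On these data alone, whether 3-cyanophenyl and 4-cyanophenyl also read alike with 4-hydroxypiperidin-1-yl or 2-(2-hydroxyethyl)piperidin-1-yl on the chain remains open. Also open, as far as these compounds go, is whether another group in place of the nitrile on the phenyl ring, such as a chlorine, an amine or a carboxylic acid, would give a step beyond the scatter.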